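The source may report more compounds than this note shows. Statements on the series, on what has been measured and on what is new or still open speak of the compounds shown alone.

Series notes. One core is shared by compound 1 `CC(C)n1ncc2c(C(=O)Nc3ccccc3)cccc21`, compound 2 `CC(C)n1ncc2c(C(=O)NCc3cn(-c4cccc(Br)c4)nn3)cccc21` and the unmeasured compound 3 `CC(C)n1ncc2c(C(=O)NCc3cn(Cc4ccc(C#N)cc4)nn3)cccc21`. In a functional assay on MGC-803 cells (Homo sapiens) for inhibition, read by MTT assay, with a stated time of 72 h (on this read-out lower numbers stand for stronger inhibition and higher numbers for weaker inhibition), compound 1 gives 38500 nM. In this assay compound 2 gives > 40000 nM, which is a limit of the assay and not a number. Within the data shown here, on the values so far compound 2 thus stands at the limit with no number of its own, as the limit of > 40000 nM in this assay, at which 1 of the 2 values shown sits, records for one of the two values in hand. Compound 3 differs from compound 2 by 4-cyanobenzyl in place of 3-bromophenyl on an aromatic nitrogen. Among the measured compounds shown here, no step between two measured compounds is available to weigh this change, and the two values in hand give no direction for it. The expected step from compound 2 to compound 3 is therefore a step that the limit leaves unreadable from compound 2 to compound 3, nothing beyond the scatter. Compound 3 is expected at 45000 nM in this assay, within a range from 20000 nM to 110000 nM, and a further limit rather than a number is quite possible.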

Compound 3, half-maximal inhibitory concentration: 39600 nM
For compound 3 the middle estimate is 1.1-fold (0.06 log units) above the measured one; the range from low to high includes it.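

With 4-cyanobenzyl on this aromatic nitrogen, compound 3 gives a number in this assay: 39600 nM. Compound 2, with 3-bromophenyl at the same place, stands at > 40000 nM, which is a limit of the assay and not a number. The change reads as a number no higher from compound 2 to compound 3 (the limit leaves the size open), and how large it is cannot be read: the limit of > 40000 nM in this assay, at which 1 of the 3 values shown sits.

The 4-cyanobenzyl group differs from 3-bromophenyl in more than one feature, so the compounds shown do not separate the part of the methylene link from that of the nitrile or the loss of bromine. Also open, on these data alone, is how a plain benzyl, a 3-bromobenzyl, a carboxylic acid or an amine on a longer chain at this nitrogen would read in this assay.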